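This account rests on a few compounds, and the source may have more. Where it says the series, first, only, none or still open, it means among the compounds named here.

Measured so far:
compound 1 `c1ccc2c(c1)CC2CCCCN1CCN(c2cccc3c2OCCO3)CC1` — 7.15 mg/kg
compound 2 `c1ccc2c(c1)CC(CCCN1CCN(c3cccc4c3OCCO4)CC1)C2` — 1.73 mg/kg

In an assay for activation of Adrenergic receptor alpha-1 (Rattus norvegicus) (on this read-out higher numbers stand for an effect only at larger amounts of compound and lower numbers for an effect already at smaller amounts), compound 2 gives the lowest of the two numbers; the nearest is compound 1, and the step from compound 1 to compound 2 was a 4.1-fold lower number from compound 1 to compound 2 (0.62 log units; beyond the scatter). Compound 3 `Clc1cccc2c1CC2CCCN1CCN(c2cccc3c2OCCO3)CC1` has not yet been measured. Its change from compound 2 is a group of 9 heavy atoms (8 carbon, 1 chlorine; one four-membered non-aromatic ring of carbon only, one six-membered aromatic ring of carbon only) in place of a group of 9 heavy atoms (9 carbon; one five-membered non-aromatic ring of carbon only, one six-membered aromatic ring of carbon only), on a saturated chain carbon, three bonds along the chain from an amine nitrogen in a ring. Going by the values given here, the only measured step that bears on this is the one from compound 1 to compound 2, where a four-membered non-aromatic ring gave way to a five-membered one and the number fell modestly. Among the compounds with values here, compound 3 returns to a four-membered ring, so part of that earlier fall is expected to reverse; the chlorine that enters has no counterpart among the measured compounds, and its effect is unknown. The number for compound 3 is therefore expected to rise moderately, about a 2.3-fold higher number from compound 2 to compound 3 (0.36 log units; beyond the scatter). The estimate for compound 3 is 4 mg/kg, with a range from 1.5 mg/kg to 12 mg/kg.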

Compound 3, dose for half-maximal effect: 1.25 mg/kg
Compound 3: middle estimate off by 3.2-fold (0.51 log units), on the high side; the whole stated range lies above it.
By their numbers in this assay, from the lowest: compounds 3 and 2 (each within the scatter of the next); then compound 1.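

In this assay, a four-membered ring at this place does not by itself go with a higher number: the chlorine-bearing group cannot be told apart from the 2,3-dihydro-1H-inden-2-yl group (a 1.4-fold lower number from compound 2 to compound 3 (0.14 log units; within the scatter)). Of the two groups with a four-membered ring, the one carrying chlorine has the lower number (a 5.7-fold lower number from compound 1 to compound 3 (0.76 log units; beyond the scatter)), so the four-membered ring and the number of compound 1 do not settle what such a group can give. Nothing available explains this result.

From the compounds shown here alone, whether the chlorine itself matters remains open, since three compounds cannot show if a fluorine or a methyl group in its stead would give a number like that of compound 3. Going by these compounds, it is also open how a chlorine on the 2,3-dihydro-1H-inden-2-yl group would compare.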